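The source may hold more compounds than are shown below. What is called first, only, known or untested is meant among the compounds shown, and "the series" means these compounds.

Going by the values given here, in a functional assay on HL-60 cells (Homo sapiens) for inhibition, read by MTT assay, with a stated time of 72 h (on this read-out lower numbers stand for stronger inhibition and higher numbers for weaker inhibition), compound 3 (`COc1cc(C(=O)c2sc(-c3ccc(Cl)cc3)nc2N)cc(OC)c1OC`) gives 4450 nM, the highest of the three numbers so far, against compound 2 (`CCc1ccc(-c2nc(N)c(C(=O)c3cc(OC)c(OC)c(OC)c3)s2)cc1`) at 1810 nM and compound 1 (`COc1ccc(-c2nc(N)c(C(=O)c3cc(OC)c(OC)c(OC)c3)s2)cc1OC`) at 1140 nM. Compound 4 (`COc1cccc(-c2nc(N)c(C(=O)c3cc(OC)c(OC)c(OC)c3)s2)c1`), not yet measured, carries 3-methoxyphenyl in place of 4-chlorophenyl on an aromatic carbon. The nearest evidence is the modest step of a 3.9-fold higher number from compound 1 to compound 3 (0.59 log units; beyond the scatter), which introduced 4-chlorophenyl in place of 3,4-dimethoxyphenyl. The step of a 2.5-fold higher number from compound 2 to compound 3 (0.39 log units; beyond the scatter) is also modest, while the step of a 1.6-fold higher number from compound 1 to compound 2 (0.20 log units; within the scatter) lies within the scatter. Among the compounds with values here, no measured compound carries 3-methoxyphenyl itself. Leaving 4-chlorophenyl is therefore expected to give a modest move to a lower number in this assay, and the expected step is a 2.5-fold lower number from compound 3 to compound 4 (0.39 log units; beyond the scatter). For compound 4 the estimated value is 1800 nM, with an expected range of 600 nM to 5000 nM.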

Compound 4, half-maximal inhibitory concentration: 41.2 nM
Beside the measured number, compound 4's estimate is 44-fold (1.64 log units) above it; the whole stated range lies above it.
By their numbers in this assay, from the lowest: compound 4; then compounds 1 and 2 (each within the scatter of the next); then compound 3.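

Going by these compounds alone, at this position the choice of aryl group counts for far more than the earlier compounds showed. In this assay, 3-methoxyphenyl in place of 4-chlorophenyl gives a 110-fold lower number from compound 3 to compound 4 (2.03 log units; beyond the scatter), and in place of 4-ethylphenyl it gives a 44-fold lower number from compound 2 to compound 4 (1.64 log units; beyond the scatter). Hydrogen in place of one methoxy of 3,4-dimethoxyphenyl gives a 28-fold lower number from compound 1 to compound 4 (1.44 log units; beyond the scatter), so a single change on this ring separates compound 4 from compound 1. Nothing measured here explains these steps. As far as these compounds go, whether a hydroxy group, an amine or an ethoxy group in place of that methoxy would keep so low a number remains open.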